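From an oxetane to a cyclopentane on the sulfonyl

The source may report more compounds than this note shows. Statements on the series, on what has been measured and on what is new or still open speak of the compounds shown alone.

Measured so far:
Compound 1 `O=C(Nc1cccc(S(=O)(=O)C2CCCC2)n1)c1ccc(NCCO)cc1N1CCC2(CC1)CC2`: 117 nM
Compound 2 `CC(C)(C)NS(=O)(=O)c1cccc(NC(=O)c2ncc(NS(C)(=O)=O)nc2N2CCC3(CC2)CC3)n1`: 32 nM
Compound 3 `O=C(Nc1cccc(S(=O)(=O)C2COC2)c1)c1cccnc1N1CCC2(CC1)CC2`: 12600 nM

Of the compounds shown here, three have been tested in a functional assay on OVCAR-3 cells (Homo sapiens) for antiproliferative activity; on this read-out higher numbers stand for an effect only at larger amounts of compound and lower numbers for an effect already at smaller amounts. Compound 3 stands at the highest of the three numbers, which here means the weakest effect. Its nearest neighbour is compound 1, and the gap between them lies well beyond the scatter; compound 2 lies further away still, also beyond the scatter.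

Compound 4 `O=C(Nc1cccc(S(=O)(=O)C2CCCC2)c1)c1cccnc1N1CCC2(CC1)CC2` is the next step, and it differs from compound 3 in one place: cyclopentyl in place of oxetan-3-yl on a sulfonyl sulfur. Among the measured compounds shown here, no measured pair shows this change on its own. Compound 1 also carries a cyclopentyl on a sulfonyl sulfur, but it differs from compound 3 in several other places as well, so the value of compound 1, 117 nM, cannot be credited to this group alone. I expect the change to bring a moderate step toward lower numbers, a 2.5-fold lower number from compound 3 to compound 4 (0.40 log units; beyond the scatter), still within the weak range. For compound 4 the estimated value in this assay is 5000 nM, with a range from 1500 nM to 16000 nM.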

Compound 4, half-maximal effective concentration: 1240 nM
Compound 4: the middle estimate sits 4.0-fold (0.61 log units) above what was measured, outside the stated range (below it).
By their numbers in this assay, from the lowest: compound 2; then compound 1; then compound 4; then compound 3.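

In this assay, among the compounds shown here, this sulfonyl substituent turns out to matter a great deal: with the rest of the molecule unchanged, cyclopentyl in place of oxetan-3-yl gives a 10-fold lower number from compound 3 to compound 4 (1.01 log units; beyond the scatter) and so this is the first comparison here that isolates a single group. The exchange removes the ring oxygen, a hydrogen-bond acceptor, and enlarges the ring at the same time, so this one step cannot show which of the two differences counts. Nothing measured here gives a reason for the step.

From the compounds shown here alone, whether a cyclobutyl or a cyclohexyl on the same sulfonyl sulfur would give a lower or a higher number remains open, as does the effect of a tetrahydropyran-4-yl, which would keep a ring oxygen in a larger ring. Also open, going by these compounds, is whether the same exchange would give a step of similar size on the core of compound 1.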